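The source may report more compounds than this note shows. Statements on the series, on what has been measured and on what is new or still open speak of the compounds shown alone.

Measured so far:
compound 1 `CCCCNc1nc(N)nc2c1CN(C(=O)c1cnc(C)cn1)CC2`: 6.8 uM
compound 2 `CCCCNc1nc(N)nc2c1CN(C(=O)c1cscn1)CC2`: 0.5 uM

In an assay on HEK293 cells for agonist activity at Toll-like receptor 8 (Homo sapiens), read by a luciferase reporter, with a stated time of 6 h (on this read-out higher numbers stand for an effect only at larger amounts of compound and lower numbers for an effect already at smaller amounts), compound 2 has the lowest number of the two, and its nearest neighbour is compound 1, with a step of a 14-fold lower number from compound 1 to compound 2 (1.13 log units; beyond the scatter) between them. Compound 3 `CCCCNc1nc(N)nc2c1CN(C(=O)c1scnc1C)CC2` differs from compound 2 in one place: 4-methyl-1,3-thiazol-5-yl in place of 1,3-thiazol-4-yl on a carbonyl carbon. Within the data shown here, no measured step covers this change; the only step known, from a six-membered ring to a five-membered one, concerns another exchange. A step no larger than the scatter, in either direction, is therefore expected, a 2.0-fold higher number from compound 2 to compound 3 (0.30 log units; within the scatter). For compound 3 the estimate in this assay is 1 uM, within 0.3 uM to 4 uM.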

Compound 3, minimum effective concentration: 5.6 uM
For compound 3 the middle estimate is 5.6-fold (0.75 log units) below the measured one; measured number above the stated range.
By their numbers in this assay, from the lowest: compound 2; then compounds 3 and 1 (each within the scatter of the next).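

In this assay, a five-membered ring with the same hetero atoms does not by itself preserve the low number: this exchange on the carbonyl carbon gives an 11-fold higher number from compound 2 to compound 3 (1.05 log units; beyond the scatter). Ring size alone therefore cannot describe the earlier step, as a five-membered and a six-membered ring are matched by a 1.2-fold lower number from compound 1 to compound 3 (0.08 log units; within the scatter). Nothing available explains the change.

As far as these compounds go, the exchange both adds a methyl and changes the ring position bonded to the carbonyl, so the contribution of each remains open. A plain 1,3-thiazol-5-yl group or 4-methyl-1,3-thiazol-2-yl group would be needed to separate them.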